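Chloro to methyl at a lone measured value

This account rests on a few compounds, and the source may have more. Where it says the series, first, only, none or still open, it means among the compounds named here.

Among the measured compounds shown here, in a functional assay on P388 cells (Mus musculus) for inhibition (on this read-out lower numbers stand for stronger inhibition and higher numbers for weaker inhibition), compound 2 `O=C1/C(=C/c2cccc(Cl)c2)Cc2ccccc21` gives 26300 nM, the only true number among the three compounds measured. Compound 1 `O=C1/C(=C/c2ccc(F)cc2)Cc2ccccc21` gives > 50000 nM, which is a limit of the assay. Compound 3 `O=C1/C(=C/c2ccc(Br)cc2)Cc2ccccc21` gives > 50000 nM, again a limit. For the measured compounds named here, the single step between measured compounds, a step that the two limits leave unreadable from compound 1 to compound 3, exchanges bromo for fluoro and offers no size to carry over. Compound 4 `Cc1cccc(/C=C2\Cc3ccccc3C2=O)c1` differs from compound 2 by methyl in place of chloro on an aromatic carbon. With compound 2 at 26300 nM and no readable step to draw on, no shift beyond the scatter is expected in this assay. The expected size is a 1.1-fold higher number from compound 2 to compound 4 (0.06 log units; within the scatter). For compound 4 the estimate is 30000 nM, with an expected range of 14000 nM to 50000 nM.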

Compound 4, half-maximal inhibitory concentration: 24900 nM
Estimate against measurement, compound 4: 1.2-fold (0.08 log units) above; low and high end bracket the measured number.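

In this assay, among the compounds shown here, this change gives the first step with a readable size: a 1.1-fold lower number from compound 2 to compound 4 (0.02 log units; within the scatter). In this place, on an aromatic carbon meta to a large group, the read-out does not tell methyl and chloro apart, and compound 4 joins compound 2 as a second true number. The other compounds shown offer no such number: the limit of > 50000 nM in this assay, at which 2 of the 4 values shown sit.

From the compounds shown here alone, whether an amine, a carboxylic acid or a longer chain in this place would shift the number beyond the scatter stays open. So does how far the number can fall on the shared core.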